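Amine tail change on the quinoline ether series

The compounds below may be only part of what the source reports. "The series", "measured", "known", "first", "only" and "open" are said of these compounds alone.

Compound 1 `COc1cc2c(Oc3ccc(NC(=O)c4nn(-c5cccc(F)c5)c(=O)c5ccccc45)cc3F)ccnc2cc1OCCCN1CCCC1` is the reference of this pair. In a functional assay on MDA-MB-231 cells (Homo sapiens) for cytotoxicity, read by MTT assay, with a stated time of 72 h (on this read-out lower numbers stand for stronger inhibition and higher numbers for weaker inhibition), compound 1 gives 880 nM. Compound 2 `COc1cc2c(Oc3ccc(NC(=O)c4nn(-c5ccc(Br)cc5)c(=O)c5ccccc45)cc3F)ccnc2cc1OCCCN1CCCC1` differs only at the aryl on the aromatic nitrogen; in this assay compound 2 gives 1160 nM, and the step of a 1.3-fold higher number from compound 1 to compound 2 (0.12 log units; within the scatter) does not separate the two compounds beyond the scatter. Compound 1 thus stands on two numbers that are effectively level.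

Compound 3 `COc1cc2c(Oc3ccc(NC(=O)c4nn(-c5cccc(F)c5)c(=O)c5ccccc45)cc3F)ccnc2cc1OCCCN1CCC(C)CC1` keeps the aryl of compound 1 and changes the amine tail: 4-methylpiperidin-1-yl in place of pyrrolidin-1-yl on a saturated chain carbon, three bonds along the chain from an oxygen on an aromatic ring. For the measured compounds named here, no measured step touches this position; the only step available, from compound 1 to compound 2, sits elsewhere on the molecule and was itself within the scatter, so it offers no read on the size or direction of an amine change. With nothing to argue for a shift, the expectation for this assay is no step beyond the scatter. The expected step is a 1.0-fold higher number from compound 1 to compound 3 (0.01 log units; within the scatter). Compound 3 is therefore estimated at 900 nM, with a range from 400 nM to 2200 nM.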

Compound 3, half-maximal inhibitory concentration: 860 nM
For compound 3 the middle estimate is 1.0-fold (0.02 log units) above the measured one, and the stated range covers the measured number.
By their numbers in this assay, from the lowest: compounds 3, 1 and 2 (each within the scatter of the next).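

In this assay, the amine tail now has a measured step of its own, a 1.0-fold lower number from compound 1 to compound 3 (0.01 log units; within the scatter), and this gives the first read on this position, which the aryl step could not provide. On the saturated chain carbon, three bonds along the chain from an oxygen on an aromatic ring, replacing the five-membered pyrrolidin-1-yl with the six-membered 4-methylpiperidin-1-yl adds two carbon atoms without separating the two compounds in this assay, so this single change gives no sign that the number depends on which of these two amine rings is present. No measured information bears on this result, so it stands as an observation without an explanation.

Open, on these data alone, is whether a tail with a second ring hetero atom, such as morpholin-4-yl or 4-methylpiperazin-1-yl, or an open-chain dimethylamino group, would give a step beyond the scatter in this assay. Also open, as far as these compounds go, are how a shorter or longer chain than 3-(4-methylpiperidin-1-yl)propyl would read and whether 4-methylpiperidin-1-yl would read the same alongside the 4-bromophenyl group of compound 2.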